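A Dimethylamino to Diethylamino Swap on Two Related Cores

The source may hold more compounds than are shown below. What is called first, only, known or untested is meant among the compounds shown, and "the series" means these compounds.

Compound 1 `CN(C)CCn1c(N)c(-c2nc3ccccc3n2C)c2nc(C#N)c(C#N)nc21` and compound 2 `CCN(CC)CCn1c(N)c(-c2nc3ccccc3n2C)c2nc(C#N)c(C#N)nc21` share one core and differ in the way described by diethylamino in place of dimethylamino on a saturated chain carbon, two bonds along the chain from an aromatic nitrogen. In a functional assay on HeLa cells (Homo sapiens) for antiproliferative activity, read by MTT assay, with a stated time of 48 h (on this read-out higher numbers stand for weaker inhibition and lower numbers for stronger inhibition), compound 1 gives > 50000 nM, which is a limit of the assay rather than a number. In this assay compound 2 likewise gives > 50000 nM, again a limit. The step that the two limits leave unreadable from compound 1 to compound 2 therefore cannot be read, because both values sit at the limit of > 50000 nM in this assay, at which 2 of the 3 values shown sit.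

Compound 3 `CN(C)CCCCn1c(-c2c(N)n(C)c3nc(C#N)c(C#N)nc23)nc2ccccc21` is built on a different core; how its core differs from that of compound 1 is not broken down here. In this assay, going by the values given here, compound 3 gives 10100 nM, the only number among the three measured compounds. Compound 4 `CCN(CC)CCCCn1c(-c2c(N)n(C)c3nc(C#N)c(C#N)nc23)nc2ccccc21` is not yet measured and differs from compound 3 as described by diethylamino in place of dimethylamino on a saturated chain carbon, four bonds along the chain from an aromatic nitrogen. Among the compounds with values here, this is the same kind of change as the one from compound 1 to compound 2, but the place is not the same: there the amine stands on a saturated chain carbon two bonds along the chain from an aromatic nitrogen, here four bonds along the chain from an aromatic nitrogen. With no readable size from the earlier pair to carry over, the expected step is estimated as a 1.0-fold lower number from compound 3 to compound 4 (0.00 log units; within the scatter). For compound 4 the estimate in this assay is 10000 nM, expected to lie between 3500 nM and 30000 nM.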

Compound 4, half-maximal inhibitory concentration: 11800 nM
For compound 4 the middle estimate is 1.2-fold (0.07 log units) below the measured one, within the range that was stated.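

In this assay, diethylamino in place of dimethylamino on a saturated chain carbon, four bonds along the chain from an aromatic nitrogen, gives a 1.2-fold higher number from compound 3 to compound 4 (0.07 log units; within the scatter), so on this core the two amines cannot be told apart. Compound 1 and compound 2 each stand at a limit of the assay and not at a number, so the same swap on their core, where the amine stands two bonds along the chain from an aromatic nitrogen, cannot be read: the limit of > 50000 nM in this assay, at which 2 of the 4 values shown sit. Going by these compounds alone, the series therefore shows only that the change leaves no readable mark on the core of compound 3; it does not show that the change carries over from one core to the other, since only one of the two pairs has a size, and the core and the place of the amine both differ between the pairs.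

The compounds shown leave open whether a ring amine such as piperidine or morpholine at the end of the same chain would read apart from dimethylamino and diethylamino on the core of compound 3. They also leave open whether a longer chain carrying diethylamino on the core of compound 1 would bring that core off the limit and give a number that could be compared.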